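Aryl variation on the saturated ring carbon of the core

The source may report more compounds than this note shows. Statements on the series, on what has been measured and on what is new or still open speak of the compounds shown alone.

Compound 1 `O=CCN1N=C(c2ccc3ccccc3c2)CC1c1ccccc1` carries a phenyl on a saturated ring carbon of the shared core; in a functional assay on PC-3 cells (Homo sapiens) for cytotoxicity, read by sulforhodamine B assay, with a stated time of 48 h (a higher number here means a weaker inhibitor, a lower number a stronger inhibitor), compound 1 gives 7400 nM. Compound 2 `COc1ccc(C2CC(c3ccc4ccccc4c3)=NN2CC=O)cc1O` carries a 3-hydroxy-4-methoxyphenyl in the same place, and compound 2 gives 2040 nM. For the measured compounds named here, the step between them, a 3.6-fold lower number from compound 1 to compound 2 (0.56 log units; beyond the scatter), is the only measured step. Going by the values given here, compound 2 therefore stands at the lower of the two numbers, with compound 1 as its only neighbour and that gap beyond the scatter.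

Compound 3 `O=CCN1N=C(c2ccc3ccccc3c2)CC1c1cccc(Br)c1` is the next variation on that ring carbon: 3-bromophenyl in place of 3-hydroxy-4-methoxyphenyl on a saturated ring carbon. Among the compounds with values here, no measured step compares a bromine-bearing phenyl with any other aryl, so the one step that bears on it is indirect: a 3.6-fold lower number from compound 1 to compound 2 (0.56 log units; beyond the scatter) shows that replacing the plain phenyl of compound 1 lowered the number modestly, but a different group entered there. With the hydroxy and methoxy of compound 2 gone, the number is expected to move back toward that of compound 1 rather than fall further, an expected step of a 2.0-fold higher number from compound 2 to compound 3 (0.29 log units; within the scatter). Compound 3 is thus estimated at 4000 nM, in a range from 1500 nM to 11000 nM.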

Compound 3, half-maximal inhibitory concentration: 10900 nM
The estimate for compound 3 lay 2.7-fold (0.44 log units) below the measured number; measured number inside the range.
By their numbers in this assay, from the lowest: compound 2; then compounds 1 and 3 (each within the scatter of the next).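

In this assay, for the compounds shown here, the low number of compound 2 does not carry over to every substituted phenyl on this saturated ring carbon: exchanging its 3-hydroxy-4-methoxyphenyl for 3-bromophenyl gives a 5.3-fold higher number from compound 2 to compound 3 (0.73 log units; beyond the scatter), a step larger than the one that first set compound 2 apart. Bromo in place of hydrogen on an aromatic carbon of the plain phenyl gives a 1.5-fold higher number from compound 1 to compound 3 (0.17 log units; within the scatter), so this read-out does not separate that pair, and substitution of the phenyl does not by itself lower the number. Among the three aryl groups, the lower number therefore goes with 3-hydroxy-4-methoxyphenyl alone, with compound 1 and compound 3 both against any broader link to substitution. No supporting measurement bears on why the number moves at this position.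

The compounds shown leave open whether the hydroxy, the methoxy or the pair of them accounts for the position of compound 2, since a phenyl bearing only one of these groups is not among them. Also open, on these data alone, is how this ring carbon responds to an aryl carrying an amine or a carboxylic acid, and whether the aryl trend holds with a longer chain in place of the formylmethyl group.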